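This account rests on a few compounds, and the source may have more. Where it says the series, first, only, none or still open, it means among the compounds named here.

- Compound 1 `O=C(Nc1ccc(Nc2ncnc3c2cnn3-c2ccccc2)cc1)Nc1ccccc1Cl`: 55100 nM
- Compound 2 `O=C(Nc1ccc(Nc2ncnc3c2cnn3-c2ccc(Cl)cc2)cc1)Nc1ccccc1Cl`: 9050 nM

Within the data shown here, in a functional assay on MCF7 cells (Homo sapiens) for cytotoxicity, read by sulforhodamine B assay, with a stated time of 72 h (a lower number here means a stronger inhibitor, a higher number a weaker inhibitor), compound 1 gives 55100 nM, the higher of the two numbers so far. Compound 3 `O=C(Nc1cccc(Cl)c1)c1ccc(Nc2ncnc3c2cnn3-c2ccccc2)cc1` keeps the core of compound 1 but swaps one side group: (3-chlorophenyl)carbamoyl in place of ((2-chlorophenyl)carbamoyl)amino on an aromatic carbon. Among the measured compounds shown here, the only measured step, a 6.1-fold lower number from compound 1 to compound 2 (0.78 log units; beyond the scatter), puts a chloro in place of hydrogen at a different place, so it does not test this swap. It only shows the size of a modest move in this small set. A modest step towards a lower number is therefore expected, though with much uncertainty. The expected step is a 2.2-fold lower number from compound 1 to compound 3 (0.34 log units; beyond the scatter). For compound 3 the estimated value is 25000 nM, with an expected range from 7000 nM to 80000 nM.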

Compound 3, half-maximal inhibitory concentration: 1120 nM
Estimate against measurement, compound 3: 22-fold (1.35 log units) above; measured number below the stated range.
By their numbers in this assay, from the lowest: compound 3; then compound 2; then compound 1.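

In this assay, the side group at this place, para to a large group, can move the number much further than the modest chloro step did: (3-chlorophenyl)carbamoyl in place of ((2-chlorophenyl)carbamoyl)amino gives a 49-fold lower number from compound 1 to compound 3 (1.69 log units; beyond the scatter), a large step. The swap changes several things at once, as the entering group has 1 hydrogen-bond donor where the leaving group has 2, and the chlorine's number in the group name also changes. No measurement here explains this gain.

Which of these changes carries the step stays open. So does how an amine or a carboxylic acid in place of the chlorine would behave.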